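The compounds below may be only part of what the source reports. "The series", "measured", "known", "first", "only" and "open" are said of these compounds alone.

Compound 1 `O=c1ccoc2cc(OCc3cn(Cc4cccc(Br)c4)nn3)ccc12` and compound 2 `O=c1ccoc2cc(OCc3cn(Cc4ccccc4Br)nn3)ccc12` share one core and differ only in where the bromine sits on the phenyl ring. In a functional assay on QGY7701 cells (Homo sapiens) for cytotoxicity, read by MTT assay, with a stated time of 48 h (on this read-out lower numbers stand for stronger inhibition and higher numbers for weaker inhibition), compound 1 gives 17600 nM. Compound 2 gives > 100000 nM, which is a limit of the assay and not a number, (the limit of > 100000 nM in this assay, at which 1 of the 2 values shown sits). Within the data shown here, the only measured step is therefore an at least 5.6-fold higher number from compound 1 to compound 2 (0.75 log units; beyond the scatter). Compound 3 `N#Cc1cccc(Cn2cc(COc3ccc4c(=O)ccoc4c3)nn2)c1` carries 3-cyanophenyl in place of 2-bromophenyl on a saturated chain carbon bound to an aromatic nitrogen. Because that measured step an at least 5.6-fold higher number from compound 1 to compound 2 (0.75 log units; beyond the scatter) weakened inhibition on leaving the 3-bromophenyl of compound 1, the return to a 3-substituted phenyl in compound 3 is expected to lower the number again. Compound 3 is estimated at 25000 nM, between 8000 nM and 100000 nM. This expected step is an at least 4.0-fold lower number from compound 2 to compound 3 (0.60 log units; beyond the scatter).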

Compound 3, half-maximal inhibitory concentration: 24400 nM
Compound 3: middle estimate off by 1.0-fold (0.01 log units), on the high side, and the stated range covers the measured number.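

Cyano in place of bromo on an aromatic carbon gives a 1.4-fold higher number from compound 1 to compound 3 (0.14 log units; within the scatter), so in this assay the 3-bromophenyl and the 3-cyanophenyl read alike. The change from 2-bromophenyl to 3-cyanophenyl gives an at least 4.0-fold lower number from compound 2 to compound 3 (0.61 log units; beyond the scatter), so among the compounds shown, the weak reading goes with the 2-bromophenyl alone. The size of that step has only a bound, as the value for compound 2 is a limit of the assay: the limit of > 100000 nM in this assay, at which 1 of the 3 values shown sits.

Still open, going by these compounds, is whether an amine or a carboxylic acid in place of the cyano would read like these two groups. Also open, on these data alone, is how a longer chain at the saturated chain carbon would read.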